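This account rests on a few compounds, and the source may have more. Where it says the series, first, only, none or still open, it means among the compounds named here.

Measured so far in an assay on isolated protein (Oryctolagus cuniculus) with Thromboxane-A synthase (Homo sapiens) as the target, tested at 1 uM; on this read-out higher numbers stand for more inhibition at the one concentration tested (going by the name of the read-out) and lower numbers for less inhibition:
compound 1, `CC(=O)OCCn1nc(-c2cccnc2)c2ccccc2c1=O`, 32%
compound 2, `O=C(O)c1ccc(Cn2nc(-c3cccnc3)c3ccccc3c2=O)cc1`, 64%

Compound 2 stands highest of the two numbers; its nearest is compound 1, and the step of a number 32 percentage points higher from compound 1 to compound 2 (beyond the scatter) lies beyond the scatter. Compound 3, `CC(C)NC(=O)CCCn1nc(-c2cccnc2)c2ccccc2c1=O`, has not yet been measured in this assay. It differs from compound 2 in one place: 2-(isopropylcarbamoyl)ethyl in place of 4-carboxyphenyl on a saturated chain carbon bound to an aromatic nitrogen. Going by the values given here, only one measured step touches this position, the step of a number 32 percentage points higher from compound 1 to compound 2 (beyond the scatter), in which acetoxymethyl gave way to 4-carboxyphenyl on the saturated chain carbon bound to the aromatic nitrogen. The change to compound 3 goes the other way, from the 4-carboxyphenyl back to a group with no ring, though the entering 2-(isopropylcarbamoyl)ethyl is not the acetoxymethyl of compound 1, so compound 1 is a guide and not a match. A drop beyond the scatter is therefore expected, likely short of a full return to the number of compound 1. The expected step is a number 24 percentage points lower from compound 2 to compound 3 (beyond the scatter). Compound 3 is estimated at 40% in this assay, within a range from 20% to 60%.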

Compound 3, a percentage reported as inhibition, at one concentration (the size of the read-out at that concentration, not a potency): 89%
The estimate for compound 3 lay 49 percentage points below the measured number; the measured number lies above the stated range.
By their numbers in this assay, from the lowest: compound 1; then compound 2; then compound 3.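

At this position, on a saturated chain carbon bound to an aromatic nitrogen, this assay shows a number 25 percentage points higher from compound 2 to compound 3 (beyond the scatter) when 4-carboxyphenyl leaves and 2-(isopropylcarbamoyl)ethyl enters, so among the three compounds shown, the six-membered aromatic ring of carbon in this group is not needed for the highest number. The groups without a ring do not sit together either: the change from the acetoxy end to the isopropylcarbamoyl end shows a number 57 percentage points higher from compound 1 to compound 3 (beyond the scatter), and compound 2, with its ring, falls between those two, so the presence or absence of a ring alone does not order the series. The groups exchanged between compound 2 and compound 3 also have equal counts of hydrogen-bond donors and acceptors and no net charge, so these counts do not follow the step.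

Which part of the entering group goes with the rise stays open: a primary amide, a cyclohexyl amide, a longer chain or a carboxylic acid on the same chain would separate the chain from the amide and from the isopropyl. The data shown offer nothing that explains these steps.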